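From cyclobutylmethyl to tert-butoxycarbonyl on the ring nitrogen

A few compounds are considered here, and "the series" means these few. Any claim that something is new, unique, unknown or untested is made for them only; others in the source may bear on it.

- compound 1 `NC(=O)c1c(NC(=O)Nc2ccc(Cl)cc2)sc2c1CCN(CC1CCCCC1)C2`: 1890 nM
- compound 2 `NC(=O)c1c(NC(=O)Nc2ccc(Cl)cc2)sc2c1CCN(CC1CCC1)C2`: 1360 nM

For the measured compounds named here, in a functional assay (strain AB) with Danio rerio as the target, read by microscopy, with a stated time of 1 h (on this read-out higher numbers stand for an effect only at larger amounts of compound and lower numbers for an effect already at smaller amounts), compound 2 gives 1360 nM, within the scatter of compound 1, the only other measured compound. Compound 3 `CC(C)(C)OC(=O)N1CCc2c(sc(NC(=O)Nc3ccc(Cl)cc3)c2C(N)=O)C1` differs from compound 2 as follows: tert-butoxycarbonyl in place of cyclobutylmethyl on an amine nitrogen in a ring. Going by the values given here, the one measured step, a 1.4-fold lower number from compound 1 to compound 2 (0.14 log units; within the scatter), swapped only the ring on a saturated chain carbon bound to an amine nitrogen in a ring. Among the compounds with values here, that step stayed within the scatter, but no measured compound carries a group like the new one, so the guidance is weak. The expected change is a 1.1-fold higher number from compound 2 to compound 3 (0.04 log units; within the scatter), with no direction favoured beyond the scatter. Compound 3 is estimated at 1500 nM, with an expected range of 400 nM to 6000 nM.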

Compound 3, half-maximal effective concentration: > 25000 nM
Compound 3: a limit, no number; the forecaster's own chance of this, stated with the estimate: 15%; middle value at least 16-fold (1.22 log units) from the limit.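

For the compounds shown here, compound 1 and compound 2 lie within the scatter of each other, which says only that the ring on the chain can be swapped. The group on the ring nitrogen proves far more sensitive, with tert-butoxycarbonyl giving an at least 18-fold higher number from compound 2 to compound 3 (1.26 log units; beyond the scatter) and an at least 13-fold higher number from compound 1 to compound 3 (1.12 log units; beyond the scatter). In this assay compound 3 gives > 25000 nM, which is a limit of the assay and not a number.

The compounds shown cannot separate the carbonyl of tert-butoxycarbonyl from its bulky carbon end. As far as these compounds go, how an acetyl group, or a plain tert-butyl group, would read on this nitrogen stays open.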